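Ester to Hydrazide: From Compound 3 Toward Compound 4

This account rests on a few compounds, and the source may have more. Where it says the series, first, only, none or still open, it means among the compounds named here.

Three analogues sharing one core have been tested in a functional assay on A549 cells (Homo sapiens) for inhibition, read by sulforhodamine B assay, with a stated time of 72 h; a higher number here means a weaker inhibitor of growth, a lower number a stronger inhibitor of growth. Compound 3 `COC(=O)/C=C/c1ccncc1-c1ccc2ccccc2c1` gives 760 nM and stands lowest of the two numbers recorded. Compound 2 `CNC(=O)/C=C/c1ccncc1-c1ccc2ccccc2c1` gives 6620 nM in this assay. Compound 1 `COC1CN(C(=O)/C=C/c2ccncc2-c2ccc3ccccc3c2)C1` gives only a limit of this assay, > 10000 nM, not a number; it is the case noted as the limit of > 10000 nM in this assay, at which 1 of the 3 values shown sits.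

Compound 4 `NNC(=O)CCc1ccncc1-c1ccc2ccccc2c1` has not yet been measured. It differs from compound 3 in one place: 2-(aminocarbamoyl)ethyl in place of 2-(methoxycarbonyl)ethenyl on an aromatic carbon. The carbonyl thus moves from an ester to a hydrazide, and the double bond of the linker is saturated.

Among the compounds with values here, two measured steps bear on this. In this assay there is an 8.7-fold lower number from compound 2 to compound 3 (0.94 log units; beyond the scatter), and an at least 13-fold lower number from compound 1 to compound 3 (1.11 log units; beyond the scatter), so both amide-type carbonyl groups gave higher numbers than the methoxy ester. Within the data shown here, the change from compound 3 to compound 4 runs the other way, from the ester toward a nitrogen-bearing carbonyl, with the added loss of the double bond, for which no step is available. Compound 4 is therefore expected to give a higher number than compound 3, by a step of roughly a 7.9-fold higher number from compound 3 to compound 4 (0.90 log units; beyond the scatter) in this assay. Compound 4 is estimated at 6000 nM, with a range from 1500 nM to 25000 nM.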

Compound 4, concentration for 50% growth inhibition: > 10000 nM
Compound 4: a limit, no number (the forecaster's own chance of this, stated with the estimate: 35%); middle value at least 1.6-fold (0.22 log units) from the limit.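

In this assay compound 4 gives no number, and it joins compound 1 at a limit of the assay: the limit of > 10000 nM in this assay, at which 2 of the 4 values shown sit.

Putting 2-(aminocarbamoyl)ethyl in place of 2-(methoxycarbonyl)ethenyl, on the aromatic carbon opposite the ring nitrogen, gives an at least 13-fold higher number from compound 3 to compound 4 (1.11 log units; beyond the scatter), so the lower number seen with the methoxy ester is lost even though the new chain also carries a carbonyl. Within the data shown here, with 2-(methylcarbamoyl)ethenyl as the group replaced, the same chain gives an at least 1.5-fold higher number from compound 2 to compound 4 (0.17 log units; that floor lies within the scatter), a floor that does not separate the two, and the methoxy ester remains the one compound whose steps to all the others lie beyond the scatter.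

The change to the hydrazide joins the replacement of the methoxy group with the saturation of the linker, so the compounds shown cannot say how much of the step belongs to either, and how far it extends past the limit cannot be read. A saturated chain ending in the methyl ester, or a double-bonded chain ending in a hydrazide or a carboxylic acid, would take the two changes apart.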